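The source may hold more compounds than are shown below. What is called first, only, known or untested is meant among the compounds shown, and "the series" means these compounds.

Working notes on the series. Compound 1 `Cc1ccc(NC2=C/C(=N/NC(N)=S)C(=O)N=C2Nc2ccc(C)cc2)cc1` serves as the reference point. In a functional assay on Bel-7402 cells (Homo sapiens) for antiproliferative activity, read by MTT assay, with a stated time of 72 h (on this read-out higher numbers stand for weaker inhibition and lower numbers for stronger inhibition), compound 1 gives 4330 nM, the second highest of the three numbers recorded. Compound 2 `NC(=S)N/N=C1/C=C(Nc2ccc(F)cc2)C(Nc2ccc(F)cc2)=NC1=O` gives 3660 nM in this assay, and compound 3 `NC(=S)N/N=C1/C=C(Nc2cccc([N+](=O)[O-])c2)C(Nc2cccc([N+](=O)[O-])c2)=NC1=O` gives 8110 nM in this assay. Both of these lie within the scatter of compound 1, so no order among the three can be drawn from the numbers in hand. Going by the values given here, no pair of measured compounds differs in a single place, so the series offers no calibrated step to lean on.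

Compound 4 `Cc1ccc(NC2=C/C(=N/N=C(\N)SCc3ccccc3)C(=O)N=C2Nc2ccc(C)cc2)cc1` differs from compound 1 in one place: a group of 11 heavy atoms (8 carbon, 2 nitrogen, 1 sulfur; one six-membered aromatic ring of carbon only) in place of a group of 4 heavy atoms (1 carbon, 2 nitrogen, 1 sulfur; no ring), on a double-bonded nitrogen. Among the compounds with values here, no measured pair tests a change of this kind, and the direction of the effect is therefore open. The expected step from compound 1 to compound 4 in this assay is a 1.4-fold lower number from compound 1 to compound 4 (0.16 log units; within the scatter), a shift not expected to clear the scatter with confidence. Compound 4 is estimated at 3000 nM in this assay, with a range from 700 nM to 13000 nM.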

Compound 4, half-maximal inhibitory concentration: 7680 nM
For compound 4 the middle estimate is 2.6-fold (0.41 log units) below the measured one; measured number inside the range.
By their numbers in this assay, from the lowest: compounds 2, 1, 4 and 3 (each within the scatter of the next, the first and the last beyond it).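

Going by these compounds alone, the single-place swap on the double-bonded nitrogen gives a 1.8-fold higher number from compound 1 to compound 4 (0.25 log units; within the scatter) in this assay, the first calibrated step. At this position, the group of 11 heavy atoms with its six-membered aromatic ring can stand in place of the group of 4 heavy atoms without a shift that clears the scatter, so the larger group is tolerated here, though one step cannot rule out a small effect in either direction. No supporting data bear on why the number stays so close to that of compound 1.

As far as these compounds go, it remains open whether a short alkyl chain, an amine or a carboxylic acid carried on the same group would also stay within the scatter. From the compounds shown here alone, it is equally open whether the same swap would behave alike on the cores of compound 2 and compound 3.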